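The compounds below may be only part of what the source reports. "The series", "measured", "known", "first", "only" and "open" are said of these compounds alone.

The measured compounds:
compound 1 `c1cc(-c2ccncn2)ccn1` gives 45%
compound 2 `Cc1cncnc1-c1ccncc1` gives 50%
compound 3 `Cc1nnc2c([n+]1[O-])CC(C(C)(C)C)CC2` gives 48%

All three were tested in a functional assay on the whole organism for inhibition, with Rattus norvegicus as the target, with stated times of 1 h and 3.5 h, at a dose of 100 mg/kg by the oral route; on this read-out lower numbers stand for less inhibition and higher numbers for more inhibition at the one dose given (going by the name of the read-out). Compound 2 and compound 1 differ in one place: hydrogen in place of methyl on an aromatic carbon. That change gave a number 5 percentage points lower from compound 2 to compound 1 (within the scatter). Compound 3 rests on a different core, and the difference between the two cores is not broken down here. Compound 4 `CC(C)(C)C1CCc2nnc[n+]([O-])c2C1` has not yet been measured; it differs from compound 3 by hydrogen in place of methyl on an aromatic carbon. This is the same kind of change as from compound 2 to compound 1, though the surroundings differ: in compound 3 the site lies on a six-membered aromatic ring with 3 nitrogen, part of a fused or bridged system of two rings, between two ring nitrogen atoms, ortho to a group of 1 heavy atom, meta and para to a fused ring, whereas in compound 2 it lies on a ring with 2 nitrogen, ortho to a group of 6 heavy atoms. Because the earlier step of a number 5 percentage points lower from compound 2 to compound 1 (within the scatter) stayed within the scatter, compound 4 is expected to show a similarly small step, a number 4 percentage points lower from compound 3 to compound 4 (within the scatter). Compound 4 is estimated in this assay at 44%, with a likely range from 30% to 58%.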

Compound 4, a percentage reported as inhibition, in the whole organism at one dose (the size of the read-out at that dose, not a potency): 36%
Beside the measured number, compound 4's estimate is 8 percentage points above it, and the stated range covers the measured number.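

Hydrogen in place of methyl on an aromatic carbon gave, in this assay, a number 12 percentage points lower from compound 3 to compound 4 (beyond the scatter). Set beside the earlier step on the other core, the result gives no sign that the two cores respond differently: the same change on two cores in this assay, a number 5 percentage points lower (within the scatter) from compound 2 to compound 1 and a number 12 percentage points lower (beyond the scatter) from compound 3 to compound 4, 7 percentage points apart, within the scatter of two such steps The change lowered the number on both cores, but this rests on only two pairs, and it shows neither that the step has a fixed size nor that it would carry to a further core.

The compounds shown leave open what other groups on this aromatic carbon would do, such as an ethyl group, an amine or a carboxylic acid. They also leave open whether the step on each core would hold at other doses.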